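The source may hold more compounds than are shown below. What is called first, only, known or untested is meant among the compounds shown, and "the series" means these compounds.

Working notes on an ADME assay on NIH3T3 cells (Mus musculus) for cytotoxicity; a lower number here means that less compound is tolerated, a higher number that more compound is tolerated. Compound 3 `CC(C)CN(NC(=O)C1CCC2(CC1)OOC1(OO2)C2CC3CC(C2)CC1C3)c1nc(C#N)ncc1Cl` gives 4500 nM. This lies within the scatter of compound 1 `CC(C)CN(NC(=O)C1CCC2(CC1)OOC1(OO2)C2CC3CC(C2)CC1C3)c1nc(C#N)ncc1Br` at 8000 nM, but compound 2 `CC(C)CN(NC(=O)C1CCC2(CC1)OOC1(OO2)C2CC3CC(C2)CC1C3)c1cc(Cl)nc(C#N)n1` at 1700 nM stands apart, with a 2.6-fold higher number from compound 2 to compound 3 (0.42 log units; beyond the scatter). Compound 4 `CC(C)CN(NC(=O)C1CCC2(CC1)OOC1(OO2)C2CC3CC(C2)CC1C3)c1ccnc(C#N)n1` comes next, with hydrogen in place of chloro on an aromatic carbon. Within the data shown here, no measured step removes a halogen outright. The nearest evidence is chloro in place of bromo in compound 3, with a 1.8-fold lower number from compound 1 to compound 3 (0.25 log units; within the scatter), while a 4.7-fold lower number from compound 1 to compound 2 (0.67 log units; beyond the scatter) concerns a different placement of the halogen. A small downward move or none is therefore expected, and the estimated change is a 1.3-fold lower number from compound 3 to compound 4 (0.11 log units; within the scatter). Compound 4 is expected at 3500 nM, within an estimated range of 1500 nM to 8000 nM.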

Compound 4, half-maximal cytotoxic concentration: 900 nM
Compound 4: middle estimate off by 3.9-fold (0.59 log units), on the high side; measured number outside the range, below it.
By their numbers in this assay, from the lowest: compounds 4 and 2 (each within the scatter of the next); then compounds 3 and 1 (each within the scatter of the next).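

In this assay the halogen on the aromatic carbon ortho to a large group counts for more than its identity: hydrogen in place of chloro gives a 5.0-fold lower number from compound 3 to compound 4 (0.70 log units; beyond the scatter), and hydrogen in place of bromo gives an 8.9-fold lower number from compound 1 to compound 4 (0.95 log units; beyond the scatter), although chloro and bromo themselves lie within the scatter. Hydrogen in place of the chloro of the 6-chloro-2-cyanopyrimidin-4-yl group gives a 1.9-fold lower number from compound 2 to compound 4 (0.28 log units; within the scatter), which stays within the scatter. Nothing measured here accounts for this difference between the two placements.

From the compounds shown here alone, whether fluoro, methyl or methoxy at the position para to the cyano group would keep the number near that of compound 3 remains open. Also open, going by these compounds, is whether a halogen at both ring carbons would go further.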